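Replacing a chain with a nitrophenylsulfonyl group on the core

The source may report more compounds than this note shows. Statements on the series, on what has been measured and on what is new or still open speak of the compounds shown alone.

Compound 1 `CCCCNC(=S)NC1=C(C#N)C(c2ccc(Cl)cc2Cl)C2=C(CCCC2=O)N1c1ccc(S(N)(=O)=O)cc1`: 40%
Compound 2 `N#CC1=C(NC(=S)Nc2ccc(Br)cc2)N(c2ccc(S(N)(=O)=O)cc2)C2=C(C(=O)CCC2)C1c1ccc(Cl)cc1Cl`: 90%

Of the compounds shown here, two have been tested in a functional assay on Ehrlich cells (Mus musculus) for cytotoxicity, read by trypan blue exclusion, with a stated time of 2 h, tested at 100 ug/mL; a higher number here means a stronger effect of the compound at the concentration tested, a lower number a weaker effect. Compound 1 gives 40%, the lower of the two numbers, and compound 2 gives 90%. Within the data shown here, the single measured step is a number 50 percentage points higher from compound 1 to compound 2 (beyond the scatter). Compound 3 `N#CC1=C(NS(=O)(=O)c2ccc([N+](=O)[O-])cc2)N(c2ccc(S(N)(=O)=O)cc2)C2=C(C(=O)CCC2)C1c1ccc(Cl)cc1Cl` differs from compound 1 as follows: a group of 12 heavy atoms (6 carbon, 1 nitrogen, 4 oxygen, 1 sulfur; one six-membered aromatic ring of carbon only) in place of a group of 7 heavy atoms (5 carbon, 1 nitrogen, 1 sulfur; no ring), on an amine nitrogen. Here too a six-membered aromatic ring enters, but through a (4-nitrophenyl)sulfonyl rather than the group seen in compound 2, so the measured step is only a loose guide. A moderate rise is expected, a number 20 percentage points higher from compound 1 to compound 3 (beyond the scatter). Compound 3 is therefore estimated at 60%, most likely between 35% and 85%.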

Compound 3, a percentage reported as activity, at one concentration (the size of the read-out at that concentration, not a potency): 90%
Compound 3: middle estimate off by 30 percentage points, on the low side, outside the stated range (above it).
By their numbers in this assay, from the lowest: compound 1; then compounds 2 and 3 (each within the scatter of the next).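

In this assay, the (4-nitrophenyl)sulfonyl group on this amine nitrogen gives a number 50 percentage points higher from compound 1 to compound 3 (beyond the scatter), so a second group with a six-membered aromatic ring also stands well clear of the ringless group of compound 1. The link and ring substituent can differ greatly without separating the two ring-bearing groups, with no change at the digits printed from compound 2 to compound 3 (within the scatter). No available evidence gives a reason for these results. From the compounds shown here alone, it remains open what the aromatic ring and the nitro group each contribute. A plain phenylsulfonyl group and a methylsulfonyl group on this nitrogen would help separate them.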